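This account rests on a few compounds, and the source may have more. Where it says the series, first, only, none or still open, it means among the compounds named here.

For the measured compounds named here, in a physicochemical assay for solubility, using the shake flask method, measured as kinetic solubility, with a stated time of 2 h, at pH 7.4 (on this read-out lower numbers stand for lower solubility and higher numbers for higher solubility), compound 2 (`CC(C)NC(=O)c1cc(N(C)Cc2ccc(C(F)(F)F)cc2)ncn1`) gives 13000 nM as the only true number so far. Compound 1 (`CN(Cc1ccc(F)cc1)c1ccnc(C(=O)Nc2ccccc2)c1`) reads < 5000 nM in this assay and that value is a limit of the assay, not a number. The change to compound 3 (`CN(Cc1ccc(C(F)(F)F)cc1)c1cc(C(=O)Nc2ncn(C)n2)ncn1`) is 1-methyl-1H-1,2,4-triazol-3-yl in place of isopropyl on an amide-type nitrogen in short, 1-methyl-1H-1,2,4-triazol-3-yl in place of isopropyl on an amide-type nitrogen. Going by the values given here, no measured step covers this change, so the expectation rests on thin ground. Compound 1 also carries a ring on its amide nitrogen and reads < 5000 nM as a limit, though its core differs. The expected step (a 2.4-fold lower number from compound 2 to compound 3 (0.37 log units; beyond the scatter)) is downward in this assay and of moderate size, just beyond the scatter. Compound 3 is estimated at 5500 nM with an expected range from 2000 nM to 15000 nM and the reading may come back as a limit.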

Compound 3, solubility: 173000 nM
For compound 3 the middle estimate is 31-fold (1.50 log units) below the measured one, and the stated range ends below it.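

For the compounds shown here, on an amide-type nitrogen of the shared core, 1-methyl-1H-1,2,4-triazol-3-yl in place of isopropyl gives a 13-fold higher number from compound 2 to compound 3 (1.12 log units; beyond the scatter) in this assay, the first measured step. A ring at this position is therefore compatible with a high reading here, and both ends of the step are true numbers. Compound 1 also carries a ring on its amide nitrogen, but its core differs and its reading remains a limit, not a number: the limit of < 5000 nM in this assay, at which 1 of the 3 values shown sits.

The compounds shown leave open whether the step follows the ring itself or its nitrogens, which a cyclohexyl or phenyl group on the same nitrogen of this core would separate. Also open, on these data alone, is how a chain ending in an amine would read at this position.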